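The source may hold more compounds than are shown below. What is called first, only, known or untested is meant among the compounds shown, and "the series" means these compounds.

Among the compounds with values here, in a functional assay on KB cells (Homo sapiens) for antiproliferative activity, read by sulforhodamine B assay, with a stated time of 3 days (a higher number here means that more compound is needed for the effect, a lower number that less compound is needed), compound 3 `CCC1=C(O)c2c(oc(-c3cccc(C)c3)cc2=O)C(CC)(CC)C1=O` gives 49.7 uM, the only number among the three measured values. Compound 1 `CCCc1ccc(-c2cc(=O)c3c(o2)C(CC)(CC)C(=O)C(CC)=C3O)cc1` reaches only the limit of > 53 uM. Compound 2 `CCC1=C(O)c2c(oc(-c3ccc(Br)cc3)cc2=O)C(CC)(CC)C1=O` likewise stops at the limit of > 48.1 uM. Within the data shown here, the step of an at least 1.0-fold lower number from compound 1 to compound 3 (0.02 log units; that floor lies within the scatter) is the one readable step and lies within the scatter, while the steps a step that the two limits leave unreadable from compound 1 to compound 2 and a step that the limit leaves unreadable from compound 2 to compound 3 cannot be sized. Compound 4 `CCC1=C(O)c2c(oc(-c3ccc(C)c(F)c3)cc2=O)C(CC)(CC)C1=O` carries 3-fluoro-4-methylphenyl in place of 3-methylphenyl on an aromatic carbon. Among the measured compounds shown here, none of the measured steps adds or removes a fluorine, so no step beyond the scatter is expected for this change. The step of a 1.0-fold higher number from compound 3 to compound 4 (0.00 log units; within the scatter) is expected to stay within the scatter. Compound 4 is estimated at 50 uM, with a range from 25 uM to 100 uM.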

Compound 4, concentration for half-maximal effect: 28.1 uM
Beside the measured number, compound 4's estimate is 1.8-fold (0.25 log units) above it; low and high end bracket the measured number.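

Within the data shown here, with a fluorine now on the aromatic ring next to the ring oxygen, this assay gives the first step of this kind: a 1.8-fold lower number from compound 3 to compound 4 (0.25 log units; within the scatter). The replacement of 3-methylphenyl by 3-fluoro-4-methylphenyl thus stays within the scatter, though it alters two things at once. The other two comparisons, an at least 1.7-fold lower number from compound 2 to compound 4 (0.23 log units; that floor lies within the scatter) and an at least 1.8-fold lower number from compound 1 to compound 4 (0.27 log units; that floor lies within the scatter), rest on limits of the assay and give floors, not sizes, and neither floor goes beyond the scatter.

From the compounds shown here alone, what 4-methylphenyl alone would give remains open, so the fluorine cannot be separated from the shift of the methyl. Also open, going by these compounds, is whether an amine or a carboxylic acid on this ring would give a step beyond the scatter.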